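Compound 2 to compound 3: a pyrrolidin-1-yl exchange

The compounds below may be only part of what the source reports. "The series", "measured", "known", "first", "only" and "open" are said of these compounds alone.

Measured so far in a functional assay on BXPC-3 cells (Homo sapiens) for cytotoxicity, read by fluorescence, with a stated time of 48 h; on this read-out higher numbers stand for an effect only at larger amounts of compound and lower numbers for an effect already at smaller amounts:
- compound 1 `CC(C)=CCC/C(C)=C/CC/C(C)=C/CSC[C@H](NC(=O)CCCCCN1CCN(C)CC1)C(=O)NC1CCCCCC1`: 6200 nM
- compound 2 `CC(C)=CCC/C(C)=C/CC/C(C)=C/CSC[C@H](NC(=O)CCCCCN1CCN(C)CC1)C(=O)NC1CC1`: 6300 nM

Of these two measurements, compound 2 at 6300 nM stands level with compound 1 at 6200 nM, and the two cannot be told apart within the scatter. The next compound to be read is compound 3 `CC(C)=CCC/C(C)=C/CC/C(C)=C/CSC[C@H](NC(=O)CCCCCN1CCN(C)CC1)C(=O)N1CCCC1`. The change is pyrrolidin-1-yl in place of cyclopropylamino on a carbonyl carbon. The hydrogen-bond donor of compound 2 leaves with the cyclopropylamino group.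

For the measured compounds named here, only one measured step bears on this: a 1.0-fold higher number from compound 1 to compound 2 (0.01 log units; within the scatter). That exchange of cycloheptyl for cyclopropyl kept the hydrogen-bond donor on the amide-type nitrogen, and it left the read-out flat. Going by the values given here, no measured step removes that donor, so the evidence is thin and the range must stay wide. No direction can be argued from two compounds.

In this assay, the expected step is a 1.0-fold higher number from compound 2 to compound 3 (0.01 log units; within the scatter), so no change beyond the scatter is anticipated. For compound 3 the estimated value is 6500 nM, with an expected range of 2800 nM to 14000 nM.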

Compound 3, half-maximal effective concentration: 3200 nM
Beside the measured number, compound 3's estimate is 2.0-fold (0.31 log units) above it, and the stated range covers the measured number.
By their numbers in this assay, from the lowest: compounds 3, 1 and 2 (each within the scatter of the next).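

In this assay, pyrrolidin-1-yl on a carbonyl carbon gives a 2.0-fold lower number from compound 2 to compound 3 (0.29 log units; within the scatter), and the same group in place of cycloheptylamino gives a 1.9-fold lower number from compound 1 to compound 3 (0.29 log units; within the scatter). The earlier comparison exchanged one ring on the amide-type nitrogen for another and kept the amide hydrogen, whereas these two exchanges remove that hydrogen-bond donor and still leave all three compounds within the scatter of each other, so across this set neither ring size nor the presence of the amide hydrogen separates the read-outs at this position. No measurement on hand accounts for this reading at the carbonyl carbon.

From the compounds shown here alone, it remains open how a simple open-chain amine such as dimethylamino, a six-membered ring such as morpholin-4-yl, or a carboxylic acid at this carbonyl carbon would read, and whether any of them would step beyond the scatter. Equally open, going by these compounds, is whether the level reading across these three compounds would persist with a shorter or longer chain in the amide arm that carries the piperazine.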